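Compound 3 against the limit of compound 1

A few compounds are considered here, and "the series" means these few. Any claim that something is new, unique, unknown or untested is made for them only; others in the source may bear on it.

Compound 1 (`O=C(Nc1ccc(C(F)(F)F)cc1)c1cccc(Nc2ncc(F)c(Nc3ccc(F)cc3)n2)c1`) gives > 10000 nM in a functional assay on KBVIN cells (Homo sapiens) for antiproliferative activity, read by sulforhodamine B assay, with a stated time of 3 days (on this read-out higher numbers stand for weaker inhibition of growth and lower numbers for stronger inhibition of growth), and this is a limit of the assay, not a number. Compound 2 (`CN1CCC(C(=O)Nc2cccc(Nc3ncc(F)c(Nc4ccc(F)cc4)n3)c2)CC1`) gives 11900 nM in this assay as a measured number. Compound 3 (`COc1cc(NC(=O)c2cccc(Nc3ncc(F)c(Nc4ccc(F)cc4)n3)c2)cc(OC)c1`) keeps the core of compound 1 and carries 3,5-dimethoxyphenyl in place of 4-(trifluoromethyl)phenyl on an amide-type nitrogen. Among the compounds with values here, no measured step covers this change, so in this assay only a small shift towards stronger inhibition of growth is expected, perhaps none beyond the scatter. The expected step (an at least 1.1-fold lower number from compound 1 to compound 3 (0.04 log units; that floor lies within the scatter)) stays small. For compound 3 the estimate is 9000 nM as the expected value, with 3000 nM to 20000 nM as its range.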

Compound 3, concentration for 50% growth inhibition: 12700 nM
For compound 3 the middle estimate is 1.4-fold (0.15 log units) below the measured one, within the range that was stated.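

In this assay compound 1 gives > 10000 nM, a limit of the assay, so the change to compound 3 cannot be read as a step: the limit of > 10000 nM in this assay, at which 1 of the 3 values shown sits.

From the compounds shown here alone, whether 3,5-dimethoxyphenyl in place of 4-(trifluoromethyl)phenyl on an amide-type nitrogen shifts inhibition of growth at all stays open.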